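Removing a Fluoro Substituent: Expected Growth Inhibition of Compound 4

The source may report more compounds than this note shows. Statements on the series, on what has been measured and on what is new or still open speak of the compounds shown alone.

Measured compounds:
Compound 1, `COc1cc(OC)cc(-c2ccc(-c3ccc(C(=N)N)c(F)c3)s2)c1`: 815 nM
Compound 2, `N=C(N)c1ccc(-c2ccc(-c3ccc(Cl)cc3)s2)cc1F`: 268 nM
Compound 3, `N=C(N)c1ccc(-c2ccc(-c3ccc(Cl)cc3)s2)cc1`: 194 nM

In a functional assay on OVCAR-3 cells (Homo sapiens) for inhibition, read by sulforhodamine B assay, with a stated time of 48 h (a higher number here means a weaker inhibitor of growth, a lower number a stronger inhibitor of growth), compound 1 gives the highest of the three numbers, and both compound 2 and compound 3 give lower numbers than it. The difference between the core of compound 1 and the core of compound 2 is not broken down here. Compound 2 and compound 3 differ in one place only, (hydrogen in place of fluoro on an aromatic carbon), and in this assay that change gave a 1.4-fold lower number from compound 2 to compound 3 (0.14 log units; within the scatter).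

Compound 4, `COc1cc(OC)cc(-c2ccc(-c3ccc(C(=N)N)cc3)s2)c1`, has not yet been measured in this assay. It differs from compound 1 by hydrogen in place of fluoro on an aromatic carbon, which is the same change as that from compound 2 to compound 3, at the same kind of place in each case. Because the step of a 1.4-fold lower number from compound 2 to compound 3 (0.14 log units; within the scatter) was small, the step from compound 1 to compound 4 is expected to be of similar size, estimated as a 1.4-fold lower number from compound 1 to compound 4 (0.13 log units; within the scatter). On that basis compound 4 is expected to give about 600 nM in this assay, most likely between 300 nM and 1200 nM.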

Compound 4, concentration for 50% growth inhibition: 1950 nM
Estimate against measurement, compound 4: 3.3-fold (0.51 log units) below; measured number outside the range, above it.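

In this assay, putting hydrogen in place of fluoro on the core of compound 1 gave a 2.4-fold higher number from compound 1 to compound 4 (0.38 log units; beyond the scatter), so on this core the compound that keeps the fluoro gives the lower number. Set beside the earlier step, the same change did not carry over from one core to the other: the same change on two cores in this assay, a 1.4-fold lower number (0.14 log units; within the scatter) from compound 2 to compound 3 and a 2.4-fold higher number (0.38 log units; beyond the scatter) from compound 1 to compound 4, 3.3-fold (0.52 log units) apart, beyond the scatter of two such steps This shows that, in this series, the step measured on one core is not a reliable guide to the step on the other, but it rests on only two pairs and does not show what sets the two cores apart or how the change would behave on any further core.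

The compounds shown carry only fluoro or hydrogen at this place, which leaves open what a hydroxyl or a methyl group there would give. Also open, from the compounds shown here alone, is how the same change would behave on a core carrying a nitrile or an amine in place of the chloro.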